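Extending the ethyl chain of a fluorinated quinoline-isoxazole

This account rests on a few compounds, and the source may have more. Where it says the series, first, only, none or still open, it means among the compounds named here.

Measured so far:
compound 1 `CCCc1cc2ccccc2nc1-c1cc(-c2ccccc2)no1`, 47200 nM
compound 2 `CCc1cc2ccccc2nc1-c1cc(-c2ccc(F)cc2)no1`, > 100000 nM

In a functional assay on MDA-MB-231 cells (Homo sapiens) for inhibition, read by MTT assay, with a stated time of 24 h (a lower number here means a stronger inhibitor, a higher number a weaker inhibitor), compound 1 gives 47200 nM. For compound 2 the same assay returns only a limit, > 100000 nM, so no number stands for it. Compound 2 therefore sits at the limit of the assay, where one of the two values shown rests (the limit of > 100000 nM in this assay, at which 1 of the 2 values shown sits), and nothing finer can be said of where it stands.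

Compound 3 `CCCc1cc2ccccc2nc1-c1cc(-c2ccc(F)cc2)no1` differs from compound 2 in one place: methyl in place of hydrogen on a saturated chain carbon, two bonds along the chain from an aromatic carbon. Read one bond further out, the change is ethyl to propyl. Among the compounds with values here, compound 1, which carries the propyl chain, is the only numbered value available, and it lies well away from the limit of this assay.

On that basis compound 3 is expected to fall close to the limit, with the step of an at least 1.4-fold lower number from compound 2 to compound 3 (0.15 log units; that floor lies within the scatter) estimated as small, at most a modest move toward stronger inhibition. The estimate for compound 3 is 70000 nM, with a range from 25000 nM to 200000 nM.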

Compound 3, half-maximal inhibitory concentration: 48400 nM
The estimate for compound 3 lay 1.4-fold (0.16 log units) above the measured number; measured number inside the range.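

In this assay, methyl in place of hydrogen on a saturated chain carbon, two bonds along the chain from an aromatic carbon, gives an at least 2.0-fold lower number from compound 2 to compound 3 (0.31 log units; beyond the scatter), so the ethyl to propyl change registers at this position. Only a bound can be given for that step, because compound 2 stands at a limit of the assay and not at a number: the limit of > 100000 nM in this assay, at which 1 of the 3 values shown sits. With the propyl chain in place, fluoro in place of hydrogen on an aromatic carbon gives a 1.0-fold higher number from compound 1 to compound 3 (0.01 log units; within the scatter), so the two propyl compounds cannot be told apart.

The compounds shown leave open whether a butyl chain at this place would push the number lower still or give the gain back. They also leave open how an amine or a hydroxyl in place of the propyl chain would read.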